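A Chloro-to-Methyl Swap Tried at a Second Site

The compounds below may be only part of what the source reports. "The series", "measured", "known", "first", "only" and "open" are said of these compounds alone.

Compound 1 `CC#C[C@@H](Cc1nnn[nH]1)c1ccc(OCc2cc(Cl)c3scc(-c4ccccc4C)c3c2)cc1`: 63 nM
Compound 2 `CC#C[C@@H](Cc1nnn[nH]1)c1ccc(OCc2ccc3sc(Cl)c(-c4ccccc4C)c3c2)cc1`: 20 nM
Compound 3 `CC#C[C@@H](Cc1nnn[nH]1)c1ccc(OCc2ccc3sc(C)c(-c4ccccc4C)c3c2)cc1`: 20 nM

Of the compounds shown here, three have been measured in a functional assay on cells for agonist activity at Free fatty acid receptor 1 (Homo sapiens), read by FLIPR and calcium flux; a lower number here means that less compound is needed, a higher number that more compound is needed for the effect. Compound 1 gives 63 nM, the highest of the three numbers. Compound 2 gives 20 nM, and compound 3 gives 20 nM; these two lie within the scatter of each other. Compound 1 and compound 2 contain the same atoms joined differently, and the difference between their two cores is not broken down here. Compound 2 and compound 3 are separated by one change, (methyl in place of chloro on an aromatic carbon), and the step of no change at the digits printed from compound 2 to compound 3 (within the scatter) is within the scatter.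

Compound 4 `CC#C[C@@H](Cc1nnn[nH]1)c1ccc(OCc2cc(C)c3scc(-c4ccccc4C)c3c2)cc1` has not yet been measured. It differs from compound 1 by methyl in place of chloro on an aromatic carbon. Among the measured compounds shown here, this is the same kind of change as the one from compound 2 to compound 3, but not the same change: there the place was on an aromatic carbon of a five-membered aromatic ring with 1 sulfur, next to the ring sulfur and next to the ring atom that bears a 2-methylphenyl group, whereas here the place is on an aromatic carbon of a six-membered aromatic ring of carbon only, ortho to a fused ring, meta to a fused ring and meta to a large group.

For the measured compounds named here, the only guide is that the earlier step of this kind was flat, because no change at the digits printed from compound 2 to compound 3 (within the scatter) stayed within the scatter. On that basis compound 4 is expected to stay close to compound 1, with an estimated step of a 1.1-fold lower number from compound 1 to compound 4 (0.02 log units; within the scatter). Compound 4 is thus estimated at 60 nM in this assay. The expected range for compound 4 runs from 25 nM to 150 nM, widened somewhat since the site of the change is a different one.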

Compound 4, half-maximal effective concentration: 134 nM
Beside the measured number, compound 4's estimate is 2.2-fold (0.35 log units) below it; the range from low to high includes it.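

In this assay, methyl in place of chloro on an aromatic carbon of the six-membered aromatic ring of carbon only gives a 2.1-fold higher number from compound 1 to compound 4 (0.33 log units; beyond the scatter), a modest step in a single pair of compounds. Set beside the flat step on the other core, this step cannot be told apart from it, even though only the new step lies beyond the scatter on its own: the same change on two cores in this assay, no change at the digits printed (within the scatter) from compound 2 to compound 3 and a 2.1-fold higher number (0.33 log units; beyond the scatter) from compound 1 to compound 4, 2.1-fold (0.33 log units) apart, within the scatter of two such steps This shows that the two cores give no firm sign of answering differently to this change, so the result is compatible with the change carrying over, but it does not prove that the change transfers, as the comparison rests on just two pairs with the change at a different place in each, and it says nothing about the reason for either step.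

From the compounds shown here alone, it remains open whether a fluoro, a methoxy or a nitrile on the same aromatic carbon would give a number closer to that of compound 1 or to that of compound 4. Going by these compounds, it is also open whether the two steps would stay alike with a plain phenyl in place of the 2-methylphenyl group.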